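The compounds below may be only part of what the source reports. "The series", "measured", "known", "first", "only" and "open" are said of these compounds alone.

In a physicochemical assay for solubility (on this read-out lower numbers stand for lower solubility and higher numbers for higher solubility), compound 1 (`C[C@H]1[C@H](N)CN1c1nc2c(cc1F)c(=O)c(C(=O)O)cn2C1CC1`) gives 23 ug/mL as a measured number. Compound 2 (`C[C@H](N)C(=O)N[C@@H](C)C(=O)N[C@@H]1CN(c2nc3c(cc2F)c(=O)c(C(=O)O)cn3C2CC2)[C@H]1C`) gives > 500 ug/mL as its reading, which is a limit of the assay and not a number. Compound 3 (`C[C@@H]1[C@@H](NC(=O)[C@@H](C)N)CN1c1nc2c(cc1F)c(=O)c(C(=O)O)cn2C1CC1`) gives > 500 ug/mL as its reading, which is also only a limit, so it stands at the limit of > 500 ug/mL in this assay, at which 2 of the 3 values shown sit, and has no exact number.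

Compound 4 (`C[C@@H](N)C(=O)N[C@@H]1CN(c2nc3c(cc2F)c(=O)c(C(=O)O)cn3C2CC2)[C@H]1C`) differs from compound 3 only in shape: the two compounds have the same atoms and bonds and differ only in configuration as drawn: 2 of 3 stereo elements differ; a stereocentre at a saturated ring carbon is drawn S in compound 3 and R in compound 4; a stereocentre at a saturated ring carbon is drawn R in compound 3 and S in compound 4, so nothing leaves and nothing enters. Among the compounds with values here, the one measured step, an at least 21-fold higher number from compound 1 to compound 2 (1.33 log units; beyond the scatter), is large and beyond the scatter, but it adds a group, whereas this change adds none. Within the data shown here, no measured step changes configuration alone, so this evidence is indirect.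

The estimated step is a step that the limit leaves unreadable from compound 3 to compound 4, which means that no step beyond the scatter is expected in this assay. Compound 4 is expected at about 600 ug/mL, with an estimated range from 250 ug/mL to 1500 ug/mL, and a reading that is only a limit would be no surprise.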

Compound 4, solubility: 495 ug/mL
Estimate against measurement, compound 4: 1.2-fold (0.08 log units) above, and the stated range covers the measured number.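

In this assay the new result is a 22-fold higher number from compound 1 to compound 4 (1.33 log units; beyond the scatter), a large step, with (1-aminoethyl)carbonyl in place of hydrogen on an amine nitrogen. Before this, a measured step at this position existed only for the longer (1-(((1-aminoethyl)carbonyl)amino)ethyl)carbonyl. The other two steps are a number no higher from compound 3 to compound 4 (the limit leaves the size open) and a number no higher from compound 2 to compound 4 (the limit leaves the size open); neither can be read in size, because compound 2 and compound 3 each stand only at a limit of the assay: the limit of > 500 ug/mL in this assay, at which 2 of the 4 values shown sit.

Going by these compounds, whether the change in configuration or the longer group moves the number therefore stays open. Also open, on these data alone, is whether a group without the amine, such as a plain acetyl, would give a step of the same size on this nitrogen.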